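A few compounds are considered here, and "the series" means these few. Any claim that something is new, unique, unknown or untested is made for them only; others in the source may bear on it.

Working notes on the series. Among the compounds with values here, compound 1 `O=C(C/C=C/c1ccccc1)Nc1nc2ccccc2c(=O)s1` is the only member with a number in an assay on CHO cells for displacement of a labelled ligand from adenosine receptor A2b (Homo sapiens), read by scintillation counting, with a stated time of 75 min; a higher number here means a weaker inhibitor, a lower number a stronger inhibitor; in this assay compound 1 gives 119 nM. Compound 2 `O=C(CCCc1cccc(Cl)c1)Nc1nc2ccccc2c(=O)s1` sits at a limit of this assay, >= 1000 nM, so no number is known for it (the limit of >= 1000 nM in this assay, at which 1 of the 2 values shown sits). Compound 3 `COc1cccc(/C=C/CC(=O)Nc2nc3ccccc3c(=O)s2)c1` differs from compound 1 by methoxy in place of hydrogen on an aromatic carbon. Within the data shown here, no step between measured compounds is available, so the size of this change in this assay is unknown; a step from compound 1 to compound 3 of about the scatter, in either direction, is expected. Compound 3 is expected to give 130 nM, in the range 50 nM to 400 nM, the expected step being a 1.1-fold higher number from compound 1 to compound 3 (0.04 log units; within the scatter).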

Compound 3, inhibition constant: >= 1000 nM
Compound 3 was reported as a limit; the forecaster's own chance of this, stated with the estimate: 10%; at least 7.6-fold (0.88 log units) between middle value and limit.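

In this assay the change from phenyl to 3-methoxyphenyl gives an at least 8.4-fold higher number from compound 1 to compound 3 (0.92 log units; beyond the scatter) and so shows a loss beyond the scatter at this position, which compound 1 alone could not show. The value of compound 3 is a limit, so this step gives only a minimum size: the limit of >= 1000 nM in this assay, at which 2 of the 3 values shown sit. Going by these compounds, whether the loss belongs to methoxy itself or to this place on the ring stays open. A fluorine or a hydroxyl on the same carbon, or methoxy on another carbon of the ring, would separate the two.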